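Inverting One Ring Stereocentre at the Cytotoxicity Limit

The source may hold more compounds than are shown below. What is called first, only, known or untested is meant among the compounds shown, and "the series" means these compounds.

Compound 1 `C[C@H](NC(=O)[C@@]1(Cc2ccccc2)CCN1C(=O)OCc1ccccc1)C(=O)NC1CCCCC1` carries a cyclohexylamino group on the carbonyl carbon, and in an ADME assay on HELF cells (Homo sapiens) for cytotoxicity, with a stated time of 3 days (a higher number here means that more compound is tolerated, a lower number that less compound is tolerated), compound 1 gives 46000 nM. Compound 2 `C[C@H](NC(=O)[C@@]1(Cc2ccccc2)CCN1C(=O)OCc1ccccc1)C(=O)N(C)C` differs from it only in that place, with dimethylamino in place of cyclohexylamino. In this assay compound 2 reaches only a limit of the assay, > 100000 nM. Among the measured compounds shown here, the single measured step is an at least 2.1-fold higher number from compound 1 to compound 2 (0.33 log units; beyond the scatter). Compound 3 `C[C@H](NC(=O)[C@]1(Cc2ccccc2)CCN1C(=O)OCc1ccccc1)C(=O)NC(C)(C)C` carries a tert-butylamino group on the carbonyl carbon, with the stereocentre at the saturated ring carbon drawn S. In this assay compound 3 likewise returns only a limit, > 100000 nM. Compound 3 therefore stands where most of the series sits, at the limit of > 100000 nM in this assay, at which 2 of the 3 values shown sit. Compound 4 `C[C@H](NC(=O)[C@@]1(Cc2ccccc2)CCN1C(=O)OCc1ccccc1)C(=O)NC(C)(C)C` is its counterpart: the two compounds have the same atoms and bonds and differ only in configuration as drawn: 1 of 2 stereo elements differ; a stereocentre at a saturated ring carbon is drawn S in compound 3 and R in compound 4. For the measured compounds named here, no measured step bears on a change of configuration alone; the one step in hand concerns the amide substituent and is at most modest. Since compound 3 is already at the limit, the expected step is a number no higher from compound 3 to compound 4 (the limit leaves the size open), nothing beyond the scatter. For compound 4 in this assay the estimate is 100000 nM, with a range from 40000 nM to 300000 nM, and compound 4 is expected most likely to be reported again as a limit.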

Compound 4, half-maximal cytotoxic concentration: > 100000 nM
Compound 4: a limit, no number; the forecaster's own chance of this, stated with the estimate: 70%; the middle value sits exactly at the limit.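

In this assay compound 4 gives > 100000 nM, a limit of the assay and not a number, so the change from S to R at the saturated ring carbon shows no readable effect, and the steps that link compound 4 to compound 3 and to compound 2 cannot be read. What the new result adds at this position is that both drawn forms of the tert-butylamino amide lie at the limit, and any comparison of them concerns configuration alone: the fact that compounds 3 and 4 differ only in the configuration as drawn. Among the compounds shown here, at the amide nitrogen, tert-butyl in place of cyclohexyl gives an at least 2.1-fold higher number from compound 1 to compound 4 (0.33 log units; beyond the scatter), which leaves the cyclohexylamino compound as the only one with a number and the other compounds together at the top of the range: the limit of > 100000 nM in this assay, at which 3 of the 4 values shown sit.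

The compounds shown leave open whether configuration at the ring carbon matters for a compound that gives a number in this assay, such as a cyclohexylamino amide with that carbon drawn S. Also open is how an adamantyl group or a longer alkyl chain on the amide nitrogen would read in this assay.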